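The compounds below may be only part of what the source reports. "The series", "measured", "known", "first", "only" and "open" are said of these compounds alone.

Three amides have been tested so far in a toxicity assay on HepG2 cells (Homo sapiens) for inhibition, read by resazurin assay, with a stated time of 24 h; a lower number here means that less compound is tolerated, a higher number that more compound is tolerated: compound 1 (`Cn1c([N+](=O)[O-])cnc1C(=O)NC1CC1`), compound 2 (`CN(C)C(=O)c1ncc([N+](=O)[O-])[nH]1`) and compound 3 (`O=C(c1ncc([N+](=O)[O-])[nH]1)N1CCCC1`). Compound 1 gives > 100000 nM as a limit of the assay. Compound 2 gives > 100000 nM as a limit too. Compound 3 gives > 100000 nM as a limit as well, so no number places it. The measurements so far amount to the limit of > 100000 nM in this assay, at which 3 of the 3 values shown sit, and nothing finer.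

Compound 4 (`O=C(NC1CC1)c1ncc([N+](=O)[O-])[nH]1`) differs from compound 3 in one place, and the change is cyclopropylamino in place of pyrrolidin-1-yl on a carbonyl carbon. Among the measured compounds shown here, the one measured step at that carbonyl carbon is a step that the two limits leave unreadable from compound 2 to compound 3 and it offers no size to carry over. Compound 1 also carries cyclopropylamino, and its > 100000 nM is again a limit. For the measured compounds named here, with the limit of > 100000 nM in this assay, at which 3 of the 3 values shown sit, as the only guide, no step beyond the scatter is expected in this assay in either direction. The expected change is a step that the limit leaves unreadable from compound 3 to compound 4 and no more. Compound 4 is estimated at 150000 nM with a range from 60000 nM to 400000 nM and is expected to be reported most likely as a limit too.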

Compound 4, half-maximal cytotoxic concentration: > 100000 nM
Compound 4 was reported as a limit (the forecaster's own chance of this, stated with the estimate: 88%); the middle value does not contradict the limit.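

In this assay compound 4 gives > 100000 nM, which is a limit of the assay. Among the compounds shown here, no step to compound 4 from compound 1, compound 2 or compound 3 can be read. The compounds shown leave open whether any of these changes alters how much compound is tolerated, as all that stands is a single ceiling: the limit of > 100000 nM in this assay, at which 4 of the 4 values shown sit.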